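Swapping fluoro for hydrogen on compound 3

A few compounds are considered here, and "the series" means these few. Any claim that something is new, unique, unknown or untested is made for them only; others in the source may bear on it.

Compound 1 `C/C(=N\NC(=S)Nc1ccccc1I)c1ccccn1` gives 6.1 nM here
Compound 2 `CC(=NNC(=S)Nc1ccccc1F)c1ccccn1` gives 5 nM here
Compound 3 `C/C(=N/NC(=S)Nc1ccccc1F)c1ccccn1` gives 5 nM here

All three numbers come from a functional assay on U-87MG ATCC cells (Homo sapiens) for cytotoxicity, read by MTT assay, with a stated time of 48 h (on this read-out higher numbers stand for weaker inhibition and lower numbers for stronger inhibition), and lie within the usual scatter of one another. Compound 3 stands level with compound 2 and within the scatter of compound 1.

The next structure is compound 4 `C/C(=N/NC(=S)Nc1ccccc1)c1ccccn1` and the change is hydrogen in place of fluoro on an aromatic carbon with hydrogen in place of fluoro on an aromatic carbon. Going by the values given here, the only measured step (no change at the digits printed from compound 2 to compound 3 (within the scatter)) lies within the scatter. Among the compounds with values here, it concerns a different feature (the fact that one of compounds 2 and 3 is drawn with a defined configuration and the other without, at the place where they differ) and does not touch the fluoro group, so no measurement yet shows what this swap does. The estimate therefore starts from compound 3 at 5 nM and keeps a wide range. The expected step (a 1.6-fold higher number from compound 3 to compound 4 (0.20 log units; within the scatter)) stays within the scatter in this assay and leans only slightly toward a higher number, which would mean weaker inhibition. Compound 4 is estimated at 8 nM (expected range 2.5 nM to 25 nM).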

Compound 4, half-maximal inhibitory concentration: 1.4 nM
For compound 4 the middle estimate is 5.7-fold (0.76 log units) above the measured one, and the stated range ends above it.
By their numbers in this assay, from the lowest: compound 4; then compounds 2, 3 and 1 (each within the scatter of the next).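

In this assay, going by these compounds alone, the swap of fluoro for hydrogen gives a 3.6-fold lower number from compound 3 to compound 4 (0.55 log units; beyond the scatter) and is the first step in this set to lie beyond the scatter. The lower number means stronger inhibition, so fluoro on this aromatic carbon, ortho to a large group, is not needed for activity in these cells, and here the compound with hydrogen does better. Nothing measured here bears on why the number moves with this swap.

These compounds leave open how other groups at this place would compare with hydrogen, for example a methoxy group, an amine or a carboxylic acid. They also leave open whether the same swap would have a similar effect on a compound with a different double-bond configuration.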